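Chloro Returns in Place of Trifluoromethyl on the Benzylsulfanyl Arm

The source may hold more compounds than are shown below. What is called first, only, known or untested is meant among the compounds shown, and "the series" means these compounds.

Among the three compounds measured so far, compound 2 `Cc1cc(-c2ccccc2)n(/C(N)=N/S(=O)(=O)c2cc(C)c(Cl)cc2SCc2ccc(C(F)(F)F)cc2)n1` stands lowest in a functional assay on MCF7 cells (Homo sapiens) for cytotoxicity, read by MTT assay, with a stated time of 72 h (a higher number here means a weaker inhibitor, a lower number a stronger inhibitor), at 16000 nM. Compound 3 `Cc1cc(S(=O)(=O)/N=C(\N)n2nccc2-c2ccccc2)c(SCc2ccc(C(F)(F)F)cc2)cc1Cl` gives 25000 nM, and the step of a 1.6-fold higher number from compound 2 to compound 3 (0.19 log units; within the scatter) lies within the scatter, so these two cannot be told apart. Compound 1 `Cc1cc(S(=O)(=O)/N=C(\N)n2nccc2-c2ccccc2)c(SCc2ccc(Cl)cc2)cc1Cl` gives 75000 nM, a number clearly above that of compound 2. Compound 4 `Cc1cc(-c2ccccc2)n(/C(N)=N/S(=O)(=O)c2cc(C)c(Cl)cc2SCc2cccc(Cl)c2)n1` remains to be measured; it differs from compound 2 in one place: 3-chlorophenyl in place of 4-(trifluoromethyl)phenyl on a saturated chain carbon bound to a sulfur.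

For the measured compounds named here, one measured step bears on this change. The step of a 3.0-fold lower number from compound 1 to compound 3 (0.48 log units; beyond the scatter) is the only one in which chloro and trifluoromethyl are exchanged on an aromatic carbon, and compound 4 partly reverses it, with chloro returning in place of trifluoromethyl, now as 3-chlorophenyl rather than in the arrangement of compound 1. Going by the values given here, no measured pair shows a 3-chlorophenyl directly, so the size of the expected step is taken from that single precedent. The account therefore expects a step of a 2.4-fold higher number from compound 2 to compound 4 (0.38 log units; beyond the scatter) toward a higher number in this assay, of a size comparable to a 3.0-fold lower number from compound 1 to compound 3 (0.48 log units; beyond the scatter) and beyond the scatter. Compound 4 is estimated at 38000 nM, with a range from 16000 nM to 90000 nM.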

Compound 4, half-maximal inhibitory concentration: 25000 nM
Compound 4: the middle estimate sits 1.5-fold (0.18 log units) above what was measured; low and high end bracket the measured number.
By their numbers in this assay, from the lowest: compounds 2, 3 and 4 (each within the scatter of the next); then compound 1.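

In this assay, the step of a 1.6-fold higher number from compound 2 to compound 4 (0.19 log units; within the scatter) shows that, on the saturated chain carbon bound to a sulfur, 3-chlorophenyl and 4-(trifluoromethyl)phenyl cannot be told apart. This differs from the step of a 3.0-fold lower number from compound 1 to compound 3 (0.48 log units; beyond the scatter), where the exchange of chloro and trifluoromethyl on an aromatic carbon gave a change beyond the scatter, so that earlier step does not carry over as a general rule to this change on the core of compound 2. Nothing available here offers an explanation for this difference between the two steps.

The step from compound 2 to compound 4 alters both the substituent and its place on the phenyl ring at once, and the compounds shown do not separate these two changes. They also leave open how this position would read with an amine or a carboxylic acid on the phenyl ring, or with a longer chain between the sulfur and that ring.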